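Ortho-Substituent Swap on a Shared Core Against TRPA1

This account rests on a few compounds, and the source may have more. Where it says the series, first, only, none or still open, it means among the compounds named here.

Measured compounds:
compound 1 `CCc1ccccc1-c1ccc2[nH]ncc2c1`, 584 nM
compound 2 `FC(F)(F)c1ccccc1-c1ccc2[nH]ncc2c1`, 164 nM
compound 3 `FC(F)c1ccccc1-c1ccc2[nH]ncc2c1`, 2200 nM

In an assay on CHO-TREX cells for antagonist activity at transient receptor potential cation channel subfamily A member 1 (Homo sapiens), read by FLIPR and calcium flux, with a stated time of 10 min (a higher number here means a weaker inhibitor, a lower number a stronger inhibitor), compound 1 stands second highest of the three numbers. The step of a 3.6-fold lower number from compound 1 to compound 2 (0.55 log units; beyond the scatter) was modest, as was the opposite step a 3.8-fold higher number from compound 1 to compound 3 (0.58 log units; beyond the scatter); between them, a 13-fold higher number from compound 2 to compound 3 (1.13 log units; beyond the scatter) was large. Compound 4 `N#Cc1ccccc1-c1ccc2[nH]ncc2c1` differs from compound 1 by cyano in place of ethyl on an aromatic carbon. Both earlier swaps at this position bear on the change, but they pull in opposite directions and give no shared tendency, so the outcome is open. The author expects a step of a 1.0-fold higher number from compound 1 to compound 4 (0.01 log units; within the scatter), likely not beyond the scatter. Compound 4 is therefore estimated at 600 nM, within 150 nM to 2500 nM.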

Compound 4, half-maximal inhibitory concentration: 1290 nM
Compound 4: middle estimate off by 2.2-fold (0.33 log units), on the low side, within the range that was stated.
By their numbers in this assay, from the lowest: compound 2; then compound 1; then compounds 4 and 3 (each within the scatter of the next).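

In this assay, cyano on this aromatic carbon is a loss against ethyl, with a 2.2-fold higher number from compound 1 to compound 4 (0.34 log units; beyond the scatter), and also against trifluoromethyl, with a 7.9-fold higher number from compound 2 to compound 4 (0.90 log units; beyond the scatter), so among these groups only the trifluoromethyl of compound 2 improves on ethyl. Cyano and difluoromethyl cannot be told apart, with a 1.7-fold lower number from compound 3 to compound 4 (0.23 log units; within the scatter), so two of the three replacements now stand on the weaker side of compound 1. No evidence here accounts for these differences. Going by these compounds, whether a chloro, a methoxy or an amine at this place would fall with compound 2 or with compounds 3 and 4 stays open, as does the effect of a chain longer than ethyl.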